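This account rests on a few compounds, and the source may have more. Where it says the series, first, only, none or still open, it means among the compounds named here.

Measured so far:
compound 1 `COc1cccc(Sc2c(NS(=O)(=O)c3ccc(C(C)(C)C)cc3)noc2CCCCC=O)c1` — 20 nM
compound 2 `CSc1c(NS(=O)(=O)c2ccc(C(C)(C)C)cc2)noc1C` — 35000 nM

In an assay on COS-7 cells for displacement of a labelled ligand from Endothelin receptor type B (Sus scrofa) (on this read-out higher numbers stand for weaker inhibition and lower numbers for stronger inhibition), compound 1 gives 20 nM, the lowest of the two numbers shown. Within the data shown here, compound 2, the only other measured compound, gives 35000 nM, and the gap between the two is well beyond the scatter; since the two structures differ in more than one place, no single step can be drawn from it. Compound 3 `COc1cccc(Sc2c(NS(=O)(=O)c3ccc(C(C)(C)C)cc3)noc2CCC=O)c1` differs from compound 1 in one place: formyl in place of 2-formylethyl on a saturated chain carbon, two bonds along the chain from an aromatic carbon. Among the measured compounds shown here, no step of this kind has been measured, so the expectation rests on compound 1 alone, whose value of 20 nM is the anchor. The step from compound 1 to compound 3 is expected to be a modest loss, a 3.0-fold higher number from compound 1 to compound 3 (0.48 log units; beyond the scatter), though a step within the scatter cannot be ruled out. Compound 3 is therefore estimated at 60 nM, with a range from 15 nM to 300 nM.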

Compound 3, half-maximal inhibitory concentration: 500 nM
Compound 3: the middle estimate sits 8.3-fold (0.92 log units) below what was measured; measured number outside the range, above it.
By their numbers in this assay, from the lowest: compound 1; then compound 3; then compound 2.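

In this assay the change of 2-formylethyl to formyl, on a saturated chain carbon, two bonds along the chain from an aromatic carbon, gives a 25-fold higher number from compound 1 to compound 3 (1.40 log units; beyond the scatter) and is a large step beyond the scatter. Both groups count the same one hydrogen-bond acceptor and one double bond, so what differs within this pair is the size of the group, with 4 heavy atoms leaving and 2 entering, and the read-out proves highly sensitive to that change at this position. No measurement at hand explains why the number rises so far.

From the compounds shown here alone, whether a longer chain would lower the number further or raise it remains open. It is also open whether the formyl carbonyl matters at all, since neither a carboxylic acid nor an amine on a chain of the same length appears among these compounds.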